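This account rests on a few compounds, and the source may have more. Where it says the series, first, only, none or still open, it means among the compounds named here.

Compounds measured in an assay on HEK-293T cells for displacement of a labelled ligand from transmembrane domain-containing protein TMIGD3 (Homo sapiens), read by scintillation counting and radioligand binding, with stated times of 10 min and 90 min; a lower number here means a stronger inhibitor, a higher number a weaker inhibitor:
compound 1 `CNc1nc(C#Cc2ccc(Cl)s2)nc2c1ncn2[C@H]1[C@H](O)[C@H](O)[C@]2(C(=O)OCCC3CCCCC3)C[C@H]12` gives 770 nM
compound 2 `CNc1nc(C#Cc2ccc(Cl)s2)nc2c1ncn2[C@H]1[C@H](O)[C@H](O)[C@]2(C(=O)OCc3ccccc3)C[C@H]12` gives 7.31 nM

For the measured compounds named here, compound 2 stands lowest of the two numbers; the single measured step at this position, a 110-fold lower number from compound 1 to compound 2 (2.02 log units; beyond the scatter), was large. Compound 3 `CNc1nc(C#Cc2ccc(Cl)s2)nc2c1ncn2[C@H]1[C@H](O)[C@H](O)[C@]2(C(=O)OCCc3ccccc3)C[C@H]12` carries benzyl in place of phenyl on a saturated chain carbon bound to an oxygen next to a carbonyl group. Going by the values given here, only that one step bears on the change, and it altered ring and chain together, so the weight of one added chain carbon alone cannot be read from it. A modest rise in number is expected for compound 3, a 4.1-fold higher number from compound 2 to compound 3 (0.61 log units; beyond the scatter). Compound 3 is estimated at 30 nM, between 7 nM and 150 nM.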

Compound 3, inhibition constant: 262 nM
The estimate for compound 3 lay 8.7-fold (0.94 log units) below the measured number; measured number above the stated range.
By their numbers in this assay, from the lowest: compound 2; then compound 3; then compound 1.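

In this assay, the one-carbon extension from benzyloxycarbonyl to phenethyloxycarbonyl gives a 36-fold higher number from compound 2 to compound 3 (1.55 log units; beyond the scatter), so chain length alone matters strongly at this position. With the chain length held, phenyl in place of cyclohexyl gives only a 2.9-fold lower number from compound 1 to compound 3 (0.47 log units; beyond the scatter), a smaller change than the one from the added carbon. Nothing measured here explains either step. The compounds shown leave open how a longer chain ending in phenyl, or an amine on the aromatic ring of the benzyl group, would read in this assay.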